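The compounds below may be only part of what the source reports. "The series", "measured", "known", "first", "only" and "open" are said of these compounds alone.

Measured in an ADME assay on a cell-free system (plasma, Mus musculus) for protein binding, using equilibrium dialysis:
- Compound 1 `CC(C)c1coc(-c2cccc(CNc3ccc4[nH]nc(C(=O)O)c4c3)c2O)n1`: > 99.7%
- Compound 2 `CN(C)c1noc(-c2cccc(CNc3ccc4[nH]nc(C(=O)O)c4c3)c2)n1`: 99%

Compound 1 stands at the edge of what this assay can report: its > 99.7% is a limit and not a number. Compound 3 `CC(C)c1noc(-c2cccc(CNc3ccc4[nH]nc(C(=O)O)c4c3)c2O)n1` keeps the core of compound 1 but carries 3-isopropyl-1,2,4-oxadiazol-5-yl in place of 4-isopropyl-1,3-oxazol-2-yl, on an aromatic carbon ortho to a hydroxy group (3-isopropyl-1,2,4-oxadiazol-5-yl in place of 4-isopropyl-1,3-oxazol-2-yl on an aromatic carbon). Among the measured compounds shown here, no measured pair shows this swap, so any forecast is uncertain. Binding stays very high in the other measured compound, because compound 2 gives 99%, so compound 3 is expected to keep very high binding as well. The expected move is an at least 2.0-fold higher unbound fraction from compound 1 to compound 3 (0.30 log units; that floor lies within the scatter), a small drop in binding at most, and possibly nothing beyond the scatter. For compound 3 the estimated value is 99.4%, with an expected range from 98.5% to 99.8%.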

Compound 3, plasma protein binding: 99.6%
Compound 3: middle estimate off by 1.5-fold (0.18 log units) (unbound fraction), on the high side; the measured number falls inside the stated range.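

The swap of 4-isopropyl-1,3-oxazol-2-yl for 3-isopropyl-1,2,4-oxadiazol-5-yl, on an aromatic carbon ortho to a hydroxy group, leaves binding very high in this assay, where compound 3 gives 99.6%. Compound 1 gives > 99.7%, which is a limit of the assay and not a number. The swap therefore gives only an at least 1.3-fold higher unbound fraction from compound 1 to compound 3 (0.12 log units; that floor lies within the scatter), and its true size stays unknown because one end of the step is not a number: the limit of > 99.7% in this assay, at which 1 of the 3 values shown sits.

The compounds shown leave open whether a morpholine or a cyclopropyl group in place of the isopropyl on the five-membered ring would free more of the compound from plasma protein. They also leave open what a primary amide in place of the carboxylic acid would do to binding on this core.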